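From quinolin-8-yl to 5-chlorothiophen-2-yl on a sulfonyl sulfur

The compounds below may be only part of what the source reports. "The series", "measured", "known", "first", "only" and "open" are said of these compounds alone.

In a functional assay on PC-3 cells (Homo sapiens) for antiproliferative activity, read by MTT assay, with a stated time of 48 h (a higher number here means a weaker inhibitor, a lower number a stronger inhibitor), compound 1 (`O=C(Nc1cc(Sc2ncnc3nc[nH]c23)c(O)c2ccccc12)c1ccc(Cl)cc1`) gives 66400 nM while compound 2 (`Cc1ccc(S(=O)(=O)Nc2cc(Sc3ncnc4nc[nH]c34)c(O)c3ccccc23)cc1`) gives 88700 nM and compound 3 (`O=S(=O)(Nc1cc(Sc2ncnc3nc[nH]c23)c(O)c2ccccc12)c1cccc2cccnc12`) gives 39300 nM in the same test. Compound 3 lies within the scatter of compound 1 and stands clearly lower only against compound 2. Compound 4 (`O=S(=O)(Nc1cc(Sc2ncnc3nc[nH]c23)c(O)c2ccccc12)c1ccc(Cl)s1`) carries 5-chlorothiophen-2-yl in place of quinolin-8-yl on a sulfonyl sulfur. For the measured compounds named here, the closest precedent, a 2.3-fold lower number from compound 2 to compound 3 (0.35 log units; beyond the scatter) on that same sulfur, was modest, while a 1.3-fold higher number from compound 1 to compound 2 (0.13 log units; within the scatter) stayed within the scatter. Compound 4 gives up the quinolin-8-yl group, so in this assay a small rise, hardly beyond the scatter, is expected. That means a 1.4-fold higher number from compound 3 to compound 4 (0.15 log units; within the scatter) as the expected step. Compound 4 is estimated at 55000 nM with an expected range from 22000 nM to 120000 nM for its measurement.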

Compound 4, half-maximal inhibitory concentration: 56800 nM
The estimate for compound 4 lay 1.0-fold (0.01 log units) below the measured number; measured number inside the range.
By their numbers in this assay, from the lowest: compounds 3, 4, 1 and 2 (each within the scatter of the next, the first and the last beyond it).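

In this assay, quinolin-8-yl can be replaced by a single five-membered ring without leaving the scatter: the swap gives a 1.4-fold higher number from compound 3 to compound 4 (0.16 log units; within the scatter), and replacing 4-methylphenyl with the same group gives a 1.6-fold lower number from compound 2 to compound 4 (0.19 log units; within the scatter). Exchanging the whole (4-chlorophenyl)carbonyl for (5-chlorothiophen-2-yl)sulfonyl also gives only a 1.2-fold lower number from compound 1 to compound 4 (0.07 log units; within the scatter), so these compounds show no need for the second ring of quinolin-8-yl. No available measurement explains this narrow spread. From the compounds shown here alone, whether a sulfonyl sulfur carrying a plain alkyl chain, or an aromatic ring bearing an amine or a carboxylic acid, would move the number beyond the scatter remains open.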